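The source may report more compounds than this note shows. Statements on the series, on what has been measured and on what is new or still open speak of the compounds shown alone.

In a functional assay on A549 cells (Homo sapiens), read by MTT assay, with a stated time of 72 h (a higher number here means a weaker inhibitor, a lower number a stronger inhibitor), compound 1 `COc1ncnc2c1c(-c1ccccc1)cn2[C@@H]1O[C@H](CO)[C@@H](O)[C@H]1O` gives > 20000 nM, which is a limit of the assay and not a number. Among the compounds with values here, compound 2 `CNc1ncnc2c1c(-c1ccco1)cn2[C@@H]1O[C@H](CO)[C@@H](O)[C@H]1O` gives 2570 nM, the only actual number so far in this assay. Compound 3 `CNc1ncnc2c1c(-c1cc3ccccc3o1)cn2[C@@H]1O[C@H](CO)[C@@H](O)[C@H]1O` keeps the core of compound 2 but carries 1-benzofuran-2-yl in place of furan-2-yl on an aromatic carbon. Within the data shown here, no measured pair shows the effect of this change, so any forecast is uncertain, but a moderate loss of potency in this assay is expected. The expected change is a 3.1-fold higher number from compound 2 to compound 3 (0.49 log units; beyond the scatter). For compound 3 the estimated value is 8000 nM, with an expected range from 2000 nM to 20000 nM.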

Compound 3, half-maximal inhibitory concentration: > 20000 nM
Compound 3: no number, only a limit (the forecaster's own chance of this, stated with the estimate: 40%); at least 2.5-fold (0.39 log units) between middle value and limit.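

In this assay, compound 3 gives > 20000 nM, which is a limit of the assay and not a number. Placing 1-benzofuran-2-yl in place of furan-2-yl on this aromatic carbon gives an at least 7.7-fold higher number from compound 2 to compound 3 (0.89 log units; beyond the scatter), the first step that can be read at this position, and it shows that the added six-membered aromatic ring does not preserve the activity of the furan-2-yl compound. The full size of this step cannot be read from a limit: the limit of > 20000 nM in this assay, at which 2 of the 3 values shown sit.

From the compounds shown here alone, whether a smaller group at this carbon, such as a methyl group, or another five-membered aromatic ring, such as thiophen-2-yl, would give a lower number than compound 2 remains open.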